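The source may report more compounds than this note shows. Statements on the series, on what has been measured and on what is new or still open speak of the compounds shown alone.

Measured so far:
- compound 1 `Nc1nc(N)c2nc(CNc3ccc(C(=O)NC(CNC(=O)c4ccccc4C(=O)O)C(=O)O)cc3)cnc2n1`: 5.1 nM
- compound 2 `Nc1nc(N)c2nc(CNc3ccc(C(=O)NC(CCCNC(=O)c4cccc(C(=O)O)c4)C(=O)O)cc3)cnc2n1`: 7.5 nM

In a functional assay on CCRF-CEM cells (Homo sapiens) for inhibition (a higher number here means a weaker inhibitor, a lower number a stronger inhibitor), compound 1 gives 5.1 nM. In this assay, among the compounds with values here, compound 2 gives 7.5 nM, the higher of the two numbers, with compound 1 as its only neighbour and the gap between them within the scatter, so the two stand level. Within the data shown here, no step between compounds differing in one place is available for the series.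

Compound 3 `Nc1nc(N)c2nc(CNc3ccc(C(=O)NC(CCCNC(=O)c4ccc(C(=O)O)cc4)C(=O)O)cc3)cnc2n1` is not yet measured. It keeps the same atoms as compound 2, joined differently: 4-carboxyphenyl in place of 3-carboxyphenyl on a carbonyl carbon. With no comparable positional change measured among the two compounds, there is no basis for a direction, and the expected step of a 1.2-fold lower number from compound 2 to compound 3 (0.06 log units; within the scatter) is estimated as none beyond the scatter. In this assay compound 3 is expected to give about 6.5 nM, estimated between 2.5 nM and 18 nM.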

Compound 3, half-maximal inhibitory concentration: 55 nM
Beside the measured number, compound 3's estimate is 8.5-fold (0.93 log units) below it; the measured number lies above the stated range.
By their numbers in this assay, from the lowest: compounds 1 and 2 (each within the scatter of the next); then compound 3.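

In this assay, 4-carboxyphenyl in place of 3-carboxyphenyl on a carbonyl carbon brings a 7.3-fold higher number from compound 2 to compound 3 (0.87 log units; beyond the scatter) with the atoms unchanged and only joined differently. Within the data shown here, this is the first step that differs in one place, and it shows that where the carboxylic acid sits on this ring can by itself move the number beyond the scatter, here towards a weaker inhibitor. No measurement at hand accounts for this step.

A single pair leaves open whether the same change would have a similar size on the shorter chain of compound 1. It also leaves open whether a tetrazole or an amine in place of the carboxylic acid, or a longer chain, would keep the number near that of compound 2 7.5 nM or lose it.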